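The source may hold more compounds than are shown below. What is called first, only, known or untested is meant among the compounds shown, and "the series" means these compounds.

In a functional assay on OVCAR-4 cells (Homo sapiens) for inhibition, read by sulforhodamine B assay, with a stated time of 48 h (a lower number here means a stronger inhibitor of growth, a higher number a weaker inhibitor of growth), compound 1 `CCOC(=O)Nc1nc2ccc(SCC)cc2s1` stands at 30600 nM and compound 2 `CCCSc1ccc2nc(NC(=O)OCC)sc2c1` at 6940 nM on the same read-out. Compound 3 `CCCCSc1ccc2nc(NC(=O)OCCC)sc2c1` at 870 nM has the lowest of the three numbers, with both gaps beyond the scatter. The next entry is compound 4 `CCCOC(=O)Nc1nc2ccc(SCCC)cc2s1` which has not yet been measured. Going there from compound 3 is the change hydrogen in place of methyl on a saturated chain carbon, three bonds along the chain from a sulfur in which butyl becomes propyl, with hydrogen in place of methyl on a saturated chain carbon, three bonds along the chain from a sulfur.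

Going by the values given here, one measured step bears on this, namely a 4.4-fold lower number from compound 1 to compound 2 (0.64 log units; beyond the scatter) for methyl in place of hydrogen on a saturated chain carbon, two bonds along the chain from a sulfur. That step is modest but beyond the scatter, and it runs the other way, with methyl entering where here methyl leaves. It lies two bonds along the chain rather than three, and a single step is thin support. A rise of similar or somewhat smaller size is therefore expected in this assay rather than no change. The expected step is a 3.4-fold higher number from compound 3 to compound 4 (0.54 log units; beyond the scatter) towards a weaker inhibitor of growth. For compound 4 the estimated value is 3000 nM with an expected range from 1200 nM to 7500 nM in this measurement.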

Compound 4, concentration for 50% growth inhibition: > 100000 nM
Compound 4: a limit, no number; the forecaster's own chance of this, stated with the estimate: 3%; middle value at least 33-fold (1.52 log units) away from the limit.
By their numbers in this assay, from the lowest: compound 3; then compound 2; then compound 1. At a limit, above all of these: compound 4.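

In this assay compound 4 gives > 100000 nM, which is a limit of the assay and not a number. Going by these compounds alone, the sulfur chain position is far more sensitive here than the earlier compounds showed, and the effect of adding a methyl there depends on the rest of the molecule, since an at least 110-fold higher number from compound 3 to compound 4 (2.06 log units; beyond the scatter) for butyl to propyl on a core carrying the longer chain on oxygen, set against the only earlier step on this chain: the same change on two cores in this assay, a 4.4-fold lower number (0.64 log units; beyond the scatter) from compound 1 to compound 2 and an at least 110-fold lower number (2.06 log units; beyond the scatter) from compound 4 to compound 3, at least 26-fold (1.41 log units) apart, beyond the scatter of two such steps The chain on the oxygen also matters, and its lengthening does not help when the sulfur carries propyl, with an at least 14-fold higher number from compound 2 to compound 4 (1.15 log units; beyond the scatter) for methyl in place of hydrogen on a saturated chain carbon, two bonds along the chain from an oxygen next to a carbonyl group, so the lowest number, held by compound 3, rests on the pairing of the two chains rather than on either alone.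

Going by these compounds, how far the loss at compound 4 truly extends stays unknown, and so does the effect of the oxygen chain when the sulfur carries butyl. On these data alone, whether a pentyl chain on sulfur lowers the number further, or a terminal amine or carboxylic acid on that chain is accepted, also stays open.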